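This account rests on a few compounds, and the source may have more. Where it says the series, first, only, none or still open, it means among the compounds named here.

Working notes on the series.

Compound 1 `CCCn1cnc(CN2CCN(c3cccc4[nH]c(-c5ccc(C(C)(C)C)cc5)nc34)CC2)c1C` gives 12 nM in an assay on isolated protein for displacement of a labelled ligand from Gonadotropin-releasing hormone receptor (Homo sapiens); on this read-out lower numbers stand for stronger inhibition and higher numbers for weaker inhibition. Compound 2 `CCCCn1cnc(CN2CCN(c3cccc4[nH]c(-c5ccc(C(C)(C)C)cc5)nc34)CC2)c1C` gives 46 nM in this assay; the change is methyl in place of hydrogen on a saturated chain carbon, three bonds along the chain from an aromatic nitrogen, and the step is a 3.8-fold higher number from compound 1 to compound 2 (0.58 log units; beyond the scatter). Compound 3 `Cc1nc(CN2CCN(c3cccc4[nH]c(-c5ccc(C(C)(C)C)cc5)nc34)CC2)cn1C` gives 10 nM in this assay; its core differs from that of compound 1 by 1,2-dimethyl-1H-imidazol-4-yl in place of 5-methyl-1-propyl-1H-imidazol-4-yl on a saturated chain carbon bound to an amine nitrogen in a ring, and the step is a 1.2-fold lower number from compound 1 to compound 3 (0.08 log units; within the scatter), while the step from compound 2 is a 4.6-fold lower number from compound 2 to compound 3 (0.66 log units; beyond the scatter).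

Compound 4 `CCc1nc(CN2CCN(c3cccc4[nH]c(-c5ccc(C(C)(C)C)cc5)nc34)CC2)cn1C` is not yet measured. It differs from compound 3 by methyl in place of hydrogen on a saturated chain carbon bound to an aromatic carbon. This is the same kind of change as that from compound 1 to compound 2, but not the same: there the place is on a saturated chain carbon, three bonds along the chain from an aromatic nitrogen, whereas here it is on a saturated chain carbon bound to an aromatic carbon. Because the earlier step of a 3.8-fold higher number from compound 1 to compound 2 (0.58 log units; beyond the scatter) was modest and the place here differs, a smaller step is expected, estimated at a 2.0-fold higher number from compound 3 to compound 4 (0.30 log units; within the scatter). Compound 4 is expected to give about 20 nM in this assay, within 8 nM to 50 nM.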

Compound 4, half-maximal inhibitory concentration: 18 nM
Compound 4: the middle estimate sits 1.1-fold (0.05 log units) above what was measured; the measured number falls inside the stated range.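

In this assay the added methyl gives a 1.8-fold higher number from compound 3 to compound 4 (0.26 log units; within the scatter), and set beside the same change on the other core, the two steps do not separate: the same change on two cores in this assay, a 3.8-fold higher number (0.58 log units; beyond the scatter) from compound 1 to compound 2 and a 1.8-fold higher number (0.26 log units; within the scatter) from compound 3 to compound 4, 2.1-fold (0.33 log units) apart, within the scatter of two such steps. This allows the change to be treated as roughly transferable between the core of compound 1 and the core of compound 3, but with one pair per core and two different places it does not show that the step is identical, and only the first of the two steps lies beyond the scatter. Across the whole group, the exchange gives a 2.6-fold lower number from compound 2 to compound 4 (0.41 log units; beyond the scatter) and a 1.5-fold higher number from compound 1 to compound 4 (0.18 log units; within the scatter), so only the first of these two steps lies beyond the scatter.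

The compounds shown leave open whether the step continues with a longer chain, such as propyl in place of the ethyl of the 2-ethyl-1-methyl-1H-imidazol-4-yl group. Also open, going by these compounds, is what an amine or a carboxylic acid would give on that saturated chain carbon bound to an aromatic carbon.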